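The source may hold more compounds than are shown below. What is called first, only, known or untested is meant among the compounds shown, and "the series" means these compounds.

Of the compounds shown here, three share one core and have been measured. In a functional assay (aorta) with Rattus norvegicus as the target (on this read-out higher numbers stand for higher potency (the scale is a negative logarithm) and lower numbers for lower potency), compound 1 `CC1(C)C=C(n2ccccc2=O)c2cc(C(=O)c3ccco3)ccc2O1` gives 6.49. Compound 2 `Cc1ccccc1C(=O)c1ccc2c(c1)C(n1ccccc1=O)=CC(C)(C)O2` gives 6.83 in this assay, and compound 3 `CC1(C)C=C(n2ccccc2=O)c2cc(-c3ccncc3)ccc2O1` gives 6.68. Compound 3 thus stands second highest of the three, yet its steps to both neighbours, a number 0.19 log units higher from compound 1 to compound 3 (within the scatter) and a number 0.15 log units lower from compound 2 to compound 3 (within the scatter), stay within the scatter; only a number 0.34 log units higher from compound 1 to compound 2 (beyond the scatter) goes beyond it.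

Compound 4 `CC1(C)C=C(n2ccccc2=O)c2cc(C(=N)S)ccc2O1` changes the same position as those two steps: a group of 3 heavy atoms (1 carbon, 1 nitrogen, 1 sulfur; no ring) in place of a group of 6 heavy atoms (5 carbon, 1 nitrogen; one six-membered aromatic ring with 1 hetero atom), on an aromatic carbon. Both earlier changes at this position left the read-out within the scatter, but none put so small a group there, so the guidance is thin. A modest drop is expected, a number 0.48 log units lower from compound 3 to compound 4 (beyond the scatter), giving for compound 4 an estimated 6.2, with a range from 5.5 to 6.9.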

Compound 4, logarithm of the reciprocal of the active concentration, log(1/C): 6.21
Compound 4: middle estimate off by 0.01 log units, on the low side; low and high end bracket the measured number.
By their numbers in this assay, from the lowest: compounds 4, 1, 3 and 2 (each within the scatter of the next, the first and the last beyond it).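

Swapping a ring-bearing group for this small group without a ring can matter at this position: in this assay the change gives a number 0.47 log units lower from compound 3 to compound 4 (beyond the scatter) and a number 0.62 log units lower from compound 2 to compound 4 (beyond the scatter), whereas a number 0.28 log units lower from compound 1 to compound 4 (within the scatter) does not separate it from the (furan-2-yl)carbonyl group. The effect therefore depends on which group is replaced. No available evidence explains these differences. Among the compounds shown here, with only one group lacking a ring, the compounds leave open whether its small size or its sulfur and nitrogen atoms matter more. An amine, a carboxylic acid or a longer chain here could help separate the two.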